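Methoxy to ethoxy at compound 4

The compounds below may be only part of what the source reports. "The series", "measured", "known", "first", "only" and "open" are said of these compounds alone.

Measured in a functional assay on J774.A1 cells (Mus musculus) for inhibition, read by Griess assay, with stated times of 1 h and 24 h; on this read-out lower numbers stand for stronger inhibition and higher numbers for weaker inhibition:
- compound 1 `C=CCOc1ccccc1C1CC(=O)c2ccccc2O1` gives 38600 nM
- compound 2 `CC(C)=CCOc1ccccc1C1CC(=O)c2ccccc2O1` gives 34300 nM
- compound 3 `COc1ccccc1C1CC(=O)c2ccccc2O1` gives 44500 nM

Compound 3 at 44500 nM holds no distinct rank among the three, as a 1.2-fold higher number from compound 1 to compound 3 (0.06 log units; within the scatter) and a 1.3-fold higher number from compound 2 to compound 3 (0.11 log units; within the scatter) both stay inside the usual scatter.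

The next compound is compound 4 `CCOc1ccccc1C1CC(=O)c2ccccc2O1` with methyl in place of hydrogen on a saturated chain carbon bound to an oxygen on an aromatic ring and the same difference also reads methoxy to ethoxy.

Among the measured compounds shown here, no measured step is this exact exchange, but the three measured steps all fall at that same carbon. Alongside the two steps above, a 1.1-fold lower number from compound 1 to compound 2 (0.05 log units; within the scatter) completes the comparison of hydrogen, vinyl and 2-methylprop-1-en-1-yl there. For the measured compounds named here, none of the three leaves the scatter, so the series so far gives no sign that this carbon governs the number. The same is expected for the smaller methyl addition, though that remains an expectation from three compounds only.

The expected step in this assay is a 1.1-fold lower number from compound 3 to compound 4 (0.06 log units; within the scatter) and no change beyond the scatter is expected in either direction.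

Compound 4 is estimated at 39000 nM within an expected range of 26000 nM to 58000 nM on this read-out.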

Compound 4, half-maximal inhibitory concentration: 38800 nM
For compound 4 the middle estimate is 1.0-fold (0.00 log units) above the measured one, within the range that was stated.
By their numbers in this assay, from the lowest: compounds 2, 1, 4 and 3 (each within the scatter of the next).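

In this assay the exchange of methyl for hydrogen on the saturated chain carbon bound to an oxygen on an aromatic ring, methoxy to ethoxy, gives a 1.1-fold lower number from compound 3 to compound 4 (0.06 log units; within the scatter) as its directly measured step, the first at this carbon with a saturated group entering. Methyl also stands level with the two unsaturated groups, with a 1.1-fold higher number from compound 2 to compound 4 (0.05 log units; within the scatter) and with a 1.0-fold higher number from compound 1 to compound 4 (0.00 log units; within the scatter) in the same assay, so every pairing among hydrogen, methyl, vinyl and 2-methylprop-1-en-1-yl at this carbon now lies within the scatter and no compound of the four stands apart. No separate measurement accompanies these numbers to account for this flat picture.

As far as these compounds go, whether any group at this carbon can move the number beyond the scatter stays open, since a terminal amine, a carboxylic acid or a longer chain such as hexyl would test it in ways these four groups do not. Equally open, from the compounds shown here alone, is whether changes elsewhere on the shared core shift the number in this assay, as all four compounds differ only at this one carbon.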